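The compounds below may be only part of what the source reports. "The series", "measured", "known", "first", "only" and "open" are said of these compounds alone.

Measured in a functional assay on HL-60 cells (Homo sapiens) for cytotoxicity, read by MTT assay, with a stated time of 4 days; a higher number here means a weaker inhibitor, a lower number a stronger inhibitor:
Compound 1, `C=C1C(=O)[C@]23C[C@@]1(O)CC[C@H]2c1ccc(O)c(C)c1[C@@H]3Cn1cc(-c2ccc(C(F)(F)F)cc2)nn1`, gives 720 nM.
Compound 2, `C=C1C(=O)[C@]23C[C@@]1(O)CC[C@H]2c1ccc(O)c(C)c1[C@@H]3Cn1cc(-c2ccc(C)cc2)nn1`, gives 830 nM.
Compound 3, `C=C1C[C@]23C[C@@]1(O)CC[C@@H]2c1cccc(C)c1[C@@H]3Cn1cc(-c2ccc(C(F)(F)F)cc2)nn1`, gives only > 20000 nM, which is a limit of the assay and not a number.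

Compound 1 and compound 2 share one core and differ in a single place: methyl in place of trifluoromethyl on an aromatic carbon. In this assay that change gave a 1.2-fold higher number from compound 1 to compound 2 (0.06 log units; within the scatter). Compound 3 is built on another core; the difference between the core of compound 1 and the core of compound 3 is not broken down here. Compound 3 sits at the limit of > 20000 nM in this assay, at which 1 of the 3 values shown sits.

Compound 4, `C=C1C[C@]23C[C@@]1(O)CC[C@@H]2c1cccc(C)c1[C@@H]3Cn1cc(-c2ccc(C)cc2)nn1`, is not yet measured. It stands to compound 3 exactly as compound 2 stands to compound 1, the same change made on the core of compound 3: methyl in place of trifluoromethyl on an aromatic carbon. The earlier step from compound 1 to compound 2 stayed within the scatter, a 1.2-fold higher number from compound 1 to compound 2 (0.06 log units; within the scatter). On that basis the step from compound 3 to compound 4 is expected to be small as well, a step that the limit leaves unreadable from compound 3 to compound 4. Compound 4 is therefore estimated at 30000 nM, between 15000 nM and 100000 nM, and most likely this assay will again report only a limit for compound 4.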

Compound 4, half-maximal inhibitory concentration: > 20000 nM
Compound 4 was reported as a limit; the forecaster's own chance of this, stated with the estimate: 80%; the middle value is on the limit's open side.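

In this assay, compound 4 gives > 20000 nM, which is a limit of the assay and not a number. Compound 3 is also reported only as a limit, so the step between compound 3 and compound 4 cannot be read: the limit of > 20000 nM in this assay, at which 2 of the 4 values shown sit.

The compounds shown leave open whether methyl in place of trifluoromethyl changes anything on the core of compound 3, as the true values of both compounds remain unknown.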